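The source may report more compounds than this note shows. Statements on the series, on what has been measured and on what is new or still open speak of the compounds shown alone.

Measured so far:
compound 1 `CCN(C(=N)Nc1cccc2ccccc12)c1cccc2ccccc12`, 6130 nM
compound 2 `N=C(Nc1cccc2ccccc12)N(c1ccccc1)c1cccc2ccccc12`, 7930 nM
compound 3 `CN(C(=N)N(c1ccccc1)c1cccc2ccccc12)c1cccc2ccccc12`, 11000 nM

These numbers come from an assay on membranes from brain (Cavia porcellus) for binding affinity to Sigma non-opioid intracellular receptor 1 (Homo sapiens), read by radioligand binding; a higher number here means a weaker inhibitor, a lower number a stronger inhibitor. Compound 2 gives the second highest of the three, but its gaps to compound 1 and to compound 3 both lie within the scatter, so the three compounds cannot be told apart. Compound 4 `CN(C(=N)Nc1cccc2ccccc12)c1ccccc1` differs from compound 2 by methyl in place of naphthalen-1-yl on a nitrogen on an aromatic ring. For the measured compounds named here, no measured step matches this change directly; the nearest are a 1.3-fold higher number from compound 1 to compound 2 (0.11 log units; within the scatter) and a 1.4-fold higher number from compound 2 to compound 3 (0.14 log units; within the scatter), both changes at a nitrogen on an aromatic ring that left the number essentially unmoved. For this assay a step of no size beyond the scatter is therefore expected. Compound 4 is estimated at 9000 nM, with a range from 3000 nM to 30000 nM. That estimate means an expected step of a 1.1-fold higher number from compound 2 to compound 4 (0.05 log units; within the scatter).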

Compound 4, half-maximal inhibitory concentration: 2900 nM
For compound 4 the middle estimate is 3.1-fold (0.49 log units) above the measured one; the measured number lies below the stated range.
By their numbers in this assay, from the lowest: compound 4; then compounds 1, 2 and 3 (each within the scatter of the next).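

Earlier changes at a nitrogen on an aromatic ring stayed within the scatter, but this one does not: in this assay, methyl in place of naphthalen-1-yl gives a 2.7-fold lower number from compound 2 to compound 4 (0.44 log units; beyond the scatter). So at this nitrogen, the much larger naphthalen-1-yl is not needed for binding, and the smaller group gives a modest gain. No measurement here explains this gain.

Only one replacement at this nitrogen is shown, so it remains open whether the gain grows or fades with other groups there. A propyl chain or a cyclohexyl ring could help settle that.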